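A benzyl group on the free hydroxy of compound 3

The source may report more compounds than this note shows. Statements on the series, on what has been measured and on what is new or still open speak of the compounds shown alone.

Compound 1 `CCCCCCCO[C@@H]1[C@@H](O)[C@@H](OCc2ccccc2)O[C@H](CC(C)C)[C@H]1OC` gives 7 ug/mL as a measured number
Compound 2 `CCCCCCCO[C@@H]1[C@@H](O)[C@@H](OCc2ccccc2)O[C@H](CO)[C@H]1O` gives > 20 ug/mL as a limit
Compound 3 `CCCCCCCO[C@@H]1[C@@H](O)[C@@H](OCc2ccccc2)O[C@@H]2CO[C@@H](c3ccc(OC)cc3)O[C@@H]12` gives 2.5 ug/mL as a measured number

In a functional assay on MCF7 cells (Homo sapiens) for cytotoxicity, in the presence of a further agent that is not named here (a lower number here means that less compound is needed, a higher number that more compound is needed for the effect), compound 3 holds the lower of the two actual numbers, and the gap to compound 1 at 7 ug/mL lies beyond the usual scatter. Compound 2 has no actual number, only the limit > 20 ug/mL in this reading.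

Compound 4 `CCCCCCCO[C@@H]1[C@@H](OCc2ccccc2)[C@@H](OCc2ccccc2)O[C@@H]2CO[C@@H](c3ccc(OC)cc3)O[C@@H]12` departs from compound 3 in one place, by benzyl in place of hydrogen on an oxygen on a saturated carbon with benzyl in place of hydrogen on an oxygen on a saturated carbon, which reads as hydroxy to benzyloxy. Among the measured compounds shown here, no measured pair shows this change alone, so the direction stays open. The expected step of a 1.2-fold higher number from compound 3 to compound 4 (0.08 log units; within the scatter) is estimated to stay within the usual scatter, starting from compound 3 at 2.5 ug/mL as the only close reference. In this assay compound 4 is expected at 3 ug/mL within an estimated range of 1 ug/mL to 10 ug/mL as its likely span.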

Compound 4, half-maximal effective concentration: > 20 ug/mL
Compound 4 was reported as a limit (the forecaster's own chance of this, stated with the estimate: 15%); middle value at least 6.6-fold (0.82 log units) away from the limit.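

Changing hydroxy to benzyloxy on this oxygen gives an at least 8.0-fold higher number from compound 3 to compound 4 (0.90 log units; beyond the scatter) in this assay. Among the compounds shown here, this is the first comparison in the set between compounds that differ in one place, which compound 1, compound 2 and compound 3 could not offer among themselves, and it shows that this position does not accept a benzyl group without a shift beyond the scatter. Compound 4 gives > 20 ug/mL, which is a limit of the assay and not a number.

On these data alone, the full size of the step stays open because only a limit is available for compound 4: the limit of > 20 ug/mL in this assay, at which 2 of the 4 values shown sit. It also remains open whether a methyl or acetyl group on this oxygen, or an amine in place of the hydroxy, would leave the number near that of compound 3, so the shift cannot yet be assigned to losing the hydrogen or to adding the benzyl.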